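Trading a Methoxyphenyl Group for a Dichlorophenyl Group

This account rests on a few compounds, and the source may have more. Where it says the series, first, only, none or still open, it means among the compounds named here.

Among the measured compounds shown here, in a functional assay on HepG2 cells (Homo sapiens) for antiproliferative activity, read by MTT assay (a lower number here means a stronger inhibitor, a higher number a weaker inhibitor), only two compounds have been measured so far. Compound 1 (`COc1ccc(-c2ccnc(Nc3ccc([N+](=O)[O-])cc3)n2)cc1`) gives 1040 nM as its reading, and compound 2 (`Clc1ccc(Nc2nccc(-c3ccc(Cl)cc3Cl)n2)c(Cl)c1`) gives 8080 nM as its reading. Compound 1 therefore holds the lower number of the pair, which marks the stronger inhibitor, and the gap lies beyond the scatter. Compound 3 (`O=[N+]([O-])c1ccc(Nc2nccc(-c3ccc(Cl)c(Cl)c3)n2)cc1`) has not yet been measured. It has 3,4-dichlorophenyl in place of 4-methoxyphenyl on an aromatic carbon and is otherwise the same as compound 1. For the measured compounds named here, the only chlorine-bearing compound measured, compound 2 at 8080 nM in this test, is a weak guide, as it differs from compound 3 elsewhere too. A moderate weakening is expected, with a 2.4-fold higher number from compound 1 to compound 3 (0.38 log units; beyond the scatter) as the estimated step. Compound 3 is estimated at 2500 nM with an expected range of 700 nM to 9000 nM on present evidence.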

Compound 3, half-maximal inhibitory concentration: 500 nM
The estimate for compound 3 lay 5.0-fold (0.70 log units) above the measured number; the measured number lies below the stated range.
By their numbers in this assay, from the lowest: compound 3; then compound 1; then compound 2.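

Replacing 4-methoxyphenyl with 3,4-dichlorophenyl on this aromatic carbon, next to the ring nitrogen, gives a 2.1-fold lower number from compound 1 to compound 3 (0.32 log units; beyond the scatter) in this assay, so the change strengthens inhibition. Among the compounds shown here, this is the first pair that differs in only one place, giving the first direct reading of this position: the methoxy group is not needed for activity in this assay, and a ring carrying two chlorines in its place does better. Nothing available here explains the gain.

This single step cannot show whether the gain comes from losing the methoxy group, from one of the two chlorines, or from both chlorines together. An unsubstituted phenyl or a phenyl with a single chlorine at this position would help separate these possibilities, while an amine or a carboxylic acid on the ring would show how far the position accepts very different groups.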